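A few compounds are considered here, and "the series" means these few. Any claim that something is new, unique, unknown or untested is made for them only; others in the source may bear on it.

Series notes on the shared core of compound 1 `FC(F)(F)Oc1ccc(Oc2ccnc(N3CCC(NC(=S)Nc4cccnc4)CC3)c2Cl)c(Cl)c1`. Compound 1 and compound 2 `FC(F)(F)Oc1ccc(Oc2ccnc(N3CCCC(NC(=S)Nc4cccnc4)C3)c2Cl)c(Cl)c1` both carry the same large group on that core; in an assay on membranes from brain for binding affinity to Lysophosphatidylserine lipase ABHD12 (Mus musculus), read by fluorescence, with a stated time of 20 min (a lower number here means a stronger inhibitor, a higher number a weaker inhibitor), compound 1 gives 11 nM, while compound 2 gives 90000 nM. Compound 3 `COc1ccnc(N2CCC(NC(=S)Nc3cccnc3)CC2)c1` carries a methoxy where those two carry the large group. In this assay compound 3 returns only a limit of the assay, > 5000 nM, and so it stands at the weak end of the numbers shown: the limit of > 5000 nM in this assay, at which 1 of the 3 values shown sits. Compound 4 `FC(F)(F)c1ccnc(N2CCC(NC(=S)Nc3cccnc3)CC2)c1` differs from compound 3 in one place, (trifluoromethyl in place of methoxy on an aromatic carbon), and has not yet been measured. Among the compounds with values here, no pair of measured compounds spans this change, so no measured step fixes its size. The expected step in this assay is a step that the limit leaves unreadable from compound 3 to compound 4, that is, none beyond the scatter, since the large group that distinguishes compound 1 from compound 3 is still absent. Compound 4 is estimated at 20000 nM in this assay, with a range from 3000 nM to 100000 nM, and most likely again only a limit will be reported.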

Compound 4, half-maximal inhibitory concentration: 640 nM
Estimate against measurement, compound 4: 31-fold (1.49 log units) above, outside the stated range (below it).
By their numbers in this assay, from the lowest: compound 1; then compound 4; then compound 2.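

In this assay, trifluoromethyl in place of methoxy on the aromatic carbon opposite the ring nitrogen gives an at least 7.8-fold lower number from compound 3 to compound 4 (0.89 log units; beyond the scatter), so this position responds to a small group even with the large group of compound 1 absent. Among the earlier compounds, none without that large group returned a number, whereas compound 4 gives 640 nM. Compound 3 stands at a limit of the assay, so the step has a lower bound but no fixed size: the limit of > 5000 nM in this assay, at which 1 of the 4 values shown sits.

Open, on these data alone, is how a nitrile or an amine at this position would compare with trifluoromethyl. Also open, as far as these compounds go, is whether a step of this kind would carry over to a compound that keeps the rest of the core of compound 1.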